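This account rests on a few compounds, and the source may have more. Where it says the series, first, only, none or still open, it means among the compounds named here.

Series notes: aryl alkyne hydroxamates, measured in a physicochemical assay for lipophilicity; a higher number here means a more lipophilic compound, a lower number a more polar compound.

Compound 1 `NC[C@H](NC(=O)c1ccc(C#Cc2ccccc2)cc1)C(=O)NO` gives 2. Compound 2 `O=C(CNC(=O)c1ccc(C#Cc2ccccc2)cc1)NO` gives 3, and compound 3 `CC(C)(NC(=O)c1ccc(C#Cc2ccccc2)cc1)C(=O)NO` gives 3. The step of a number 1.00 log units higher from compound 1 to compound 2 (beyond the scatter) and the step of a number 1.00 log units higher from compound 1 to compound 3 (beyond the scatter) are both beyond the scatter, whereas the step of no change at the digits printed from compound 2 to compound 3 (within the scatter) is within it. Compound 3 therefore stands level with compound 2 at the digits shown, the two together the highest of the three numbers, and its furthest neighbour is compound 1.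

The next compound, compound 4 `CC(C)C(NC(=O)c1ccc(C#Cc2ccccc2)cc1)C(=O)NO`, is not yet measured in this assay. Its difference from compound 3 is 1-(hydroxycarbamoyl)-2-methylpropyl in place of 1-(hydroxycarbamoyl)-1-methylethyl on an amide-type nitrogen. The only measured step that bears directly on a change of this kind is the one from compound 2 to compound 3, where two methyl groups entered on the same chain carbon and this assay did not move at the digits shown. The steps involving compound 1 concern an aminomethyl group leaving or being exchanged and are less relevant here. On that basis, a small step of a number 0.30 log units higher from compound 3 to compound 4 (within the scatter) is expected for compound 4, upward if anything, and quite possibly within the scatter. Compound 4 is estimated at 3.3, with a range from 2.8 to 3.8.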

Compound 4, distribution coefficient: > 3
Compound 4: a limit, no number; the forecaster's own chance of this, stated with the estimate: 2%; the middle value is on the limit's open side.
By their numbers in this assay, from the lowest: compound 1; then compounds 2 and 3 (each within the scatter of the next).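

In this assay compound 4 gives > 3, a limit of the assay and not a number: the limit of > 3 in this assay, at which 1 of the 4 values shown sits. Two steps cannot be read for size, so the limit gives only their direction: 1-(hydroxycarbamoyl)-2-methylpropyl in place of 1-(hydroxycarbamoyl)-1-methylethyl on an amide-type nitrogen gives a number no lower from compound 3 to compound 4 (the limit leaves the size open) and isopropyl in place of hydrogen on a saturated chain carbon bound to an amide-type nitrogen and a carbonyl carbon gives a number no lower from compound 2 to compound 4 (the limit leaves the size open) as the second step. Among these compounds, the one readable step, a number at least 1.00 log units higher from compound 1 to compound 4 (beyond the scatter), extends to this new group what the earlier compounds showed only for compound 2 and compound 3: without the aminomethyl group of compound 1, the reading stays clear of compound 1.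

The compounds shown leave open how far compound 4 lies from compound 2 and compound 3, and so whether the isopropyl group on the saturated chain carbon counts for more in this assay than the two methyl groups of compound 3. They also leave open how a carboxylic acid or a longer chain bearing an amine at that same carbon would read against compound 1 and the other compounds.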